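Aryl swap at the chain-end amine: compound 3 to compound 4

The compounds below may be only part of what the source reports. "The series", "measured", "known", "first", "only" and "open" are said of these compounds alone.

Compound 3 `COc1ccccc1Oc1ccc2c(NCCCNCc3ccco3)ccnc2c1` gives 14500 nM in a physicochemical assay for solubility, with a stated time of 18 h, at pH 7.4; a higher number here means a more soluble compound, a lower number a less soluble compound. It stands level with compound 1 `COc1cccc(Oc2ccc3c(NCCCNCc4ccco4)ccnc3c2)c1`, which gives 14500 nM; together they hold the highest of the three numbers. Compound 2 `c1ccc(Cc2ccc3c(NCCCNCc4ccco4)ccnc3c2)cc1` gives 4200 nM and is the furthest from compound 3: a 3.5-fold higher number from compound 2 to compound 3 (0.54 log units; beyond the scatter). The two other steps recorded so far both sit on an aromatic carbon of the shared core: a 3.5-fold lower number from compound 1 to compound 2 (0.54 log units; beyond the scatter), whereas no change at the digits printed from compound 1 to compound 3 (within the scatter).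

Compound 4 `COc1ccc(F)cc1CNCCCNc1ccnc2cc(Oc3ccccc3OC)ccc12` differs from compound 3 at the opposite end of the molecule: 5-fluoro-2-methoxyphenyl in place of furan-2-yl on a saturated chain carbon bound to an amine nitrogen. Among the measured compounds shown here, none of the measured steps touches a saturated chain carbon bound to an amine nitrogen, so no step bears directly on this change. The recorded steps only give a sense of scale for single changes in this series, from no change through a modest move. The entering group is the larger of the two, and a modest decrease is therefore expected rather than an increase, with wide uncertainty: a 2.1-fold lower number from compound 3 to compound 4 (0.32 log units; beyond the scatter).

Compound 4 is accordingly estimated at 7000 nM, in the range 2500 nM to 20000 nM.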

Compound 4, solubility: 14500 nM
For compound 4 the middle estimate is 2.1-fold (0.32 log units) below the measured one; low and high end bracket the measured number.
By their numbers in this assay, from the lowest: compound 2; then compounds 1, 3 and 4 (each within the scatter of the next).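

In this assay, the first step recorded at the chain end reads no change at the digits printed from compound 3 to compound 4 (within the scatter): 5-fluoro-2-methoxyphenyl, with 9 heavy atoms, stands in for furan-2-yl, with 5, on a saturated chain carbon bound to an amine nitrogen, and the number stays put. Among the compounds shown here, at this position, then, a five-membered aromatic ring with 1 hetero atom and a six-membered aromatic ring of carbon only read alike on the compound 3 background, whereas the one step beyond the scatter at the other end of the molecule remains a 3.5-fold higher number from compound 2 to compound 3 (0.54 log units; beyond the scatter). Nothing shown gives a reason for the flat reading at the chain end.

Compounds 1 and 3 share the number of compound 4, 14500 nM, and the compounds shown do not settle whether this identical figure marks a shared upper reach of the read-out, which would leave further gains at this position unseen. Also open, from the compounds shown here alone, is whether the result holds on the benzyl background of compound 2, and what a carboxylic acid on the entering ring, a saturated cyclohexyl group in its place or a longer chain would do to the number.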